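The compounds below may be only part of what the source reports. "The series", "measured", "known", "first", "only" and "open" are said of these compounds alone.

In a functional assay on HOP-62 cells (Homo sapiens) for inhibition, read by sulforhodamine B assay, with a stated time of 48 h (a higher number here means a weaker inhibitor of growth, a lower number a stronger inhibitor of growth), compound 1 (`COc1cc(-c2nn(-c3cccc(NC(=O)c4cccc(C(F)(F)F)c4)c3)cc2-c2ccncc2)ccc1Cl`) gives only a limit, > 50000 nM, and not a number. Compound 2 (`O=C(Nc1cccc(-n2cc(-c3ccncc3)c(-c3ccc(Cl)c(O)c3)n2)c1)Nc1cc(C(F)(F)F)cc(C(F)(F)F)c1`) gives a true number in this assay, 1980 nM. Compound 3 (`COc1cc(-c2nn(-c3cccc(NC(=O)Nc4ccc(Cl)c(C(F)(F)F)c4)c3)cc2-c2ccncc2)ccc1Cl`) keeps the core of compound 1 but carries (4-chloro-3-(trifluoromethyl)phenyl)amino in place of 3-(trifluoromethyl)phenyl on a carbonyl carbon. For the measured compounds named here, no measured step covers this change, so the expectation is tentative: a large fall in this assay, towards stronger inhibition of growth, guided only by compound 2 at 1980 nM. The expected change is an at least 8.3-fold lower number from compound 1 to compound 3 (0.92 log units; beyond the scatter). For compound 3 the estimated value is 6000 nM, with an expected range of 2000 nM to 40000 nM.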

Compound 3, concentration for total growth inhibition: 6490 nM
For compound 3 the middle estimate is 1.1-fold (0.03 log units) below the measured one, and the stated range covers the measured number.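

On the carbonyl carbon, (4-chloro-3-(trifluoromethyl)phenyl)amino in place of 3-(trifluoromethyl)phenyl brings an at least 7.7-fold lower number from compound 1 to compound 3 (0.88 log units; beyond the scatter) in this assay. This single place is therefore enough to turn a limit into a true number on the shared core. The full size of the step stays unknown because one end of it is a limit: the limit of > 50000 nM in this assay, at which 1 of the 3 values shown sits.

The change brings in the amino nitrogen and the chlorine together, and the compounds shown do not separate the two. Going by these compounds, whether a methyl or a nitrile in place of that chlorine would keep the effect also remains open.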